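Adding a methoxy to compound 2

The source may report more compounds than this note shows. Statements on the series, on what has been measured and on what is new or still open speak of the compounds shown alone.

In a functional assay on the whole organism (heart, strain Wistar) for inhibition, with Rattus norvegicus as the target, with a stated time of 15 min, at a dose of 1 mg/kg by the intravenous route (a lower number here means that less compound is needed, a higher number that more compound is needed for the effect), compound 2 (`COc1ccccc1OCCNCC(O)COc1cccc2[nH]ccc12`) gives 0.34 mg/kg. This is within the scatter of compound 1 (`COc1ccccc1OCCNC[C@H](O)COc1c(OC)ccc2[nH]ccc12`) at 0.3 mg/kg, while compound 3 (`COc1ccccc1OCCNC[C@@H](O)COc1c(OC)ccc2[nH]ccc12`) at 0.16 mg/kg lies lower, beyond the scatter. Compound 4 (`COc1ccccc1OCCNCC(O)COc1ccc(OC)c2[nH]ccc12`) follows from compound 2 by methoxy in place of hydrogen on an aromatic carbon, a methoxy in place of hydrogen on an aromatic carbon. Among the measured compounds shown here, the only measured step, a 1.9-fold lower number from compound 1 to compound 3 (0.27 log units; within the scatter), comes with the fact that compounds 1 and 3 differ only in the configuration as drawn, so it does not gauge this change. Compound 1, which has a methoxy elsewhere on the core, gives 0.3 mg/kg, so no shift beyond the scatter is expected in this assay. The expected step is a 1.1-fold lower number from compound 2 to compound 4 (0.05 log units; within the scatter). For compound 4 the estimate is 0.3 mg/kg, with an expected range of 0.12 mg/kg to 0.75 mg/kg.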

Compound 4, dose for half-maximal effect: 0.45 mg/kg
The estimate for compound 4 lay 1.5-fold (0.18 log units) below the measured number, and the stated range covers the measured number.
By their numbers in this assay, from the lowest: compounds 3, 1, 2 and 4 (each within the scatter of the next, the first and the last beyond it).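

In this assay, methoxy in place of hydrogen on this aromatic carbon, ortho to a fused ring and para to a large group, gives a 1.3-fold higher number from compound 2 to compound 4 (0.12 log units; within the scatter), so the group is accommodated here without a shift beyond the scatter. The earlier compounds shown here offered no single-place comparison for this position. Nothing available accounts for the size of this step.

On these data alone, whether a larger group such as benzyloxy, or a carboxylic acid, would also stay within the scatter at this position remains open. So does how the separate configurations of compound 4 compare.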